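A few compounds are considered here, and "the series" means these few. Any claim that something is new, unique, unknown or untested is made for them only; others in the source may bear on it.

Measured compounds:
- compound 1, `COc1ccc(C2CC(c3ccc(OCc4cn(Cc5ccc([N+](=O)[O-])cc5)nn4)cc3)=NN2C(C)=O)cc1`; in a functional assay on A549 cells (Homo sapiens) for inhibition, read by sulforhodamine B assay, tested at 10 uM (a lower number here means less inhibition of growth, a higher number more inhibition of growth at the concentration tested), compound 1 gives 26%
- compound 2, `COc1cc(C2CC(c3ccccc3)=NN2C(C)=O)ccc1OCc1cn(Cc2ccc([N+](=O)[O-])cc2)nn1`; in this assay compound 2 gives 0%
- compound 3, `COc1ccc(C2=NN(C(C)=O)C(c3ccc(OCc4cn(Cc5ccc([N+](=O)[O-])cc5)nn4)c(OC)c3)C2)cc1`; in this assay compound 3 gives 43%

Compound 2 and compound 3 differ in one place only, (methoxy in place of hydrogen on an aromatic carbon). For the measured compounds named here, that step, a number 43 percentage points higher from compound 2 to compound 3 (beyond the scatter), is the one clear step inside the measured set. Going by the values given here, compound 1 is built from the same atoms as compound 2 joined differently; the difference between the two cores is not broken down here, and their values show only that compound 1 sits higher than compound 2, with compound 3 higher again than compound 1.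

Compound 4, `COc1ccc(C2CC(c3ccc(OCc4cn(Cc5ccc([N+](=O)[O-])cc5)nn4)cc3)=NN2C(C)=O)cc1OC`, is not yet measured. It stands to compound 1 as compound 3 stands to compound 2, (methoxy in place of hydrogen on an aromatic carbon). It is the same kind of change, not the same change: in compound 3 the entering methoxy sits para to a large group, in compound 4 it sits ortho to a methoxy group and meta to a large group.

Among the compounds with values here, the expectation for compound 4 rests on compound 1 at 26% and on the single earlier step, a number 43 percentage points higher from compound 2 to compound 3 (beyond the scatter). With the place of the change differing, the step is expected to be smaller than the earlier one: from compound 1 to compound 4 a step of a number 10 percentage points higher from compound 1 to compound 4 (within the scatter) is estimated in this assay. Compound 4 is thus expected to give about 36% in this assay, estimated to lie between 15% and 60%.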

Compound 4, percent growth inhibition at one concentration: 11%
Compound 4: middle estimate off by 25 percentage points, on the high side, outside the stated range (below it).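

In this assay, methoxy entering on an aromatic carbon of the shared core of compound 1, ortho to a methoxy group and meta to a large group, turns 4-methoxyphenyl into 3,4-dimethoxyphenyl and gives a number 15 percentage points lower from compound 1 to compound 4 (beyond the scatter). Within this series the change therefore does not carry over from one core to the other in either size or direction, and the earlier gain cannot be used as a general value for adding methoxy: the same change on two cores in this assay, a number 43 percentage points higher (beyond the scatter) from compound 2 to compound 3 and a number 15 percentage points lower (beyond the scatter) from compound 1 to compound 4, 58 percentage points apart, beyond the scatter of two such steps

This does not show whether the core or the place of the change accounts for the gap, as the two steps differ in both and each core supplies a single pair, so no rule for methoxy in either direction follows from them.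

The compounds shown leave open whether the same aromatic carbon on the core of compound 1 would respond differently to a group other than methoxy, such as a hydroxyl, an amine or a carboxylic acid. Also open, going by these compounds, is whether the two steps would keep their size and direction at other concentrations or on other cell lines.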